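Replacing a dichlorophenyl amide with a benzyl amide

The source may report more compounds than this note shows. Statements on the series, on what has been measured and on what is new or still open speak of the compounds shown alone.

Three compounds share one core and differ only in the amide part and the chain that joins it. Compound 1 `CC(Sc1nnc(-c2ccncc2)s1)C(=O)NCc1ccc(Cl)cc1`, compound 2 `O=C(CCSc1nnc(-c2ccncc2)s1)Nc1ccc(Cl)cc1Cl` and compound 3 `CC(CSc1nnc(-c2ccncc2)s1)C(=O)Nc1ccc(Cl)cc1Cl` are the measured set, and compound 4 `O=C(CCSc1nnc(-c2ccncc2)s1)NCc1ccccc1` is the one still to be tested. In an ADME assay on HepG2 cells (Homo sapiens) for cytotoxicity, with a stated time of 3 days (a lower number here means that less compound is tolerated, a higher number that more compound is tolerated), compound 1 gives "not determined" (no result reported). In this assay compound 2 stops at a limit of the assay, > 50000 nM. Compound 3 likewise reaches only a limit, > 50000 nM. Among the measured compounds shown here, the one measured step, a step that the two limits leave unreadable from compound 2 to compound 3, therefore cannot be sized. Compound 2 thus stands at a limit rather than at a number; of the two other entries, one is also a limit and one has no number at all.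

Compound 4 differs from compound 2 by benzyl in place of 2,4-dichlorophenyl on an amide-type nitrogen. For the measured compounds named here, no measured step touches this change, since the only step measured concerns the chain, and it is unreadable. The expectation can rest only on (the limit of > 50000 nM in this assay, at which 2 of the 3 values shown sit). Compound 4 is expected to stay at that same limit, with an estimate of 50000 nM and a range from 20000 nM to 100000 nM. The step this estimate implies, a number no higher from compound 2 to compound 4 (the limit leaves the size open), is expected to be none beyond the scatter.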

Compound 4, half-maximal cytotoxic concentration: 14000 nM
Estimate against measurement, compound 4: 3.6-fold (0.55 log units) above; measured number outside the range, below it.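

In this assay, the group on the amide-type nitrogen proves able to move the result: exchanging 2,4-dichlorophenyl for benzyl gives an at least 3.5-fold lower number from compound 2 to compound 4 (0.55 log units; beyond the scatter). Among the compounds shown here, the only earlier step, which concerned the chain, cannot be read, so this is the first sign that any structural change in the set alters how much compound the cells tolerate, and compound 4 supplies the first actual number. The true size of the step remains open, since compound 2 stands at a limit, and that limit is still the most common result in the set: the limit of > 50000 nM in this assay, at which 2 of the 4 values shown sit.

The exchange also makes two changes at once, removing both chlorine atoms and adding a carbon to the group on the nitrogen, and the compounds shown cannot separate these; a plain phenyl group or a 2,4-dichlorobenzyl group on this nitrogen would tell the two apart. Going by these compounds, it also remains open whether benzyl would give a similar step on the methyl-bearing chain of compound 3.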